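A few compounds are considered here, and "the series" means these few. Any claim that something is new, unique, unknown or untested is made for them only; others in the source may bear on it.

Of the compounds shown here, three have been measured in an assay on CHO cells with metabotropic glutamate receptor 2 (Homo sapiens) as the target, read by FLIPR; on this read-out higher numbers stand for larger maximal responses and lower numbers for smaller maximal responses. Compound 1 `Cn1c(CN2CCC(c3ccccc3)CC2)nc2ccccc21` gives 89%. Compound 3 `Cn1c(CN2CCC(c3ccc(Cl)cc3)CC2)nc2ccccc21` gives 91%, and the step of a number 2 percentage points higher from compound 1 to compound 3 (within the scatter) is within the scatter. Compound 2 `Cn1c(CN2CCN(c3ccc(Cl)cc3F)CC2)nc2ccccc21` gives 69%, the lowest of the three numbers: the nearest is compound 1, whose value is higher by an amount beyond the scatter, and the furthest is compound 3, also beyond the scatter.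

Compound 4 `Cn1c(CN2CCN(c3ccccc3F)CC2)nc2ccccc21` differs from compound 2 in one place: hydrogen in place of chloro on an aromatic carbon. Read one bond further out, the 4-chloro-2-fluorophenyl becomes a 2-fluorophenyl.

Among the measured compounds shown here, only one measured step bears on this change, and it runs the other way: chloro in place of hydrogen on an aromatic carbon, from compound 1 to compound 3, with a number 2 percentage points higher from compound 1 to compound 3 (within the scatter) inside the scatter. Compound 4 is therefore expected to move by a number 1 percentage points higher from compound 2 to compound 4 (within the scatter) in this assay, no more than the scatter allows. The estimate for compound 4 in this assay is 70%, expected to lie between 55% and 85%.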

Compound 4, largest response reached (Emax), in percent of the reference or control that the assay uses: 64%
Compound 4: middle estimate off by 6 percentage points, on the high side, within the range that was stated.
By their numbers in this assay, from the lowest: compounds 4 and 2 (each within the scatter of the next); then compounds 1 and 3 (each within the scatter of the next).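

Removing the chloro from the 4-chloro-2-fluorophenyl in this assay gives a number 5 percentage points lower from compound 2 to compound 4 (within the scatter) and so leaves the maximal response unchanged within the scatter, even with a fluoro group meta to this position. The earlier compounds shown here showed this change on one core only, with no fluoro group on the ring, so the absence of a clear shift could have been particular to that core. It now holds on two cores, and the sizes of the two steps agree: the same change on two cores in this assay, a number 2 percentage points higher (within the scatter) from compound 1 to compound 3 and a number 5 percentage points higher (within the scatter) from compound 4 to compound 2, 3 percentage points apart, within the scatter of two such steps

What the compounds shown leave open is whether any other group in this place, para to a large group, would shift the response beyond the scatter, for example a methoxy group, an amine or a carboxylic acid. They also leave open what the fluoro group itself contributes on this core.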